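Swapping the aryl group for a phenylethenyl chain

The source may report more compounds than this note shows. Statements on the series, on what has been measured and on what is new or still open speak of the compounds shown alone.

Going by the values given here, compound 2 `O=C(CSc1nnc(-c2ccncc2)o1)N/N=C/c1cc(Cl)ccc1O` gives 5830 nM in a functional assay on MCF7 cells (Homo sapiens) for cytotoxicity, read by MTT assay, with a stated time of 48 h (a higher number here means a weaker inhibitor, a lower number a stronger inhibitor), the lowest of the two numbers measured so far; compound 1 `O=C(CSc1nnc(-c2ccncc2)o1)N/N=C/c1ccc([N+](=O)[O-])cc1` gives 31800 nM. Among the compounds with values here, the only measured step, a 5.5-fold lower number from compound 1 to compound 2 (0.74 log units; beyond the scatter), shows that changing the group on this carbon can move the number well beyond the scatter. Compound 3 `O=C(CSc1nnc(-c2ccncc2)o1)N/N=C/C=C/c1ccccc1` differs from compound 2 thus: 2-phenylethenyl in place of 5-chloro-2-hydroxyphenyl on a carbon with a double bond to nitrogen. Within the data shown here, no measured step involves this chain, so the direction is uncertain; compound 3 is expected at 12000 nM (range 4000 nM to 40000 nM), an estimated step of a 2.1-fold higher number from compound 2 to compound 3 (0.31 log units; beyond the scatter).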

Compound 3, half-maximal inhibitory concentration: 10800 nM
Compound 3: the middle estimate sits 1.1-fold (0.05 log units) above what was measured; measured number inside the range.
By their numbers in this assay, from the lowest: compounds 2 and 3 (each within the scatter of the next); then compound 1.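

The step of a 1.9-fold higher number from compound 2 to compound 3 (0.27 log units; within the scatter) in this assay means that 2-phenylethenyl and 5-chloro-2-hydroxyphenyl cannot be told apart here, even though 2-phenylethenyl has no hydrogen-bond donor or acceptor and 5-chloro-2-hydroxyphenyl has one of each. So these counted features are not needed at this position to reach this level, and the chain also gives a 2.9-fold lower number from compound 1 to compound 3 (0.47 log units; beyond the scatter) when set against 4-nitrophenyl. No available measurement explains these differences. Still open, from the compounds shown here alone, is whether a longer chain, or an amine on the phenyl ring of this chain, would hold this level or move it beyond the scatter.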